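Swapping phenyl for methyl on an amide nitrogen

The compounds below may be only part of what the source reports. "The series", "measured", "known", "first", "only" and "open" are said of these compounds alone.

- compound 1 `CC[C@@H](C(=O)Nc1ccccc1)N1CCCC1=O` measured at 560 umol/kg
- compound 2 `CCCCCCN(CCCCCC)C(=O)[C@H](CC)N1CCCC1=O` measured at 560 umol/kg

In a functional assay on the whole organism with Mus musculus as the target (on this read-out higher numbers stand for an effect only at larger amounts of compound and lower numbers for an effect already at smaller amounts), compound 1 gives 560 umol/kg and stands level with compound 2 at 560 umol/kg on the digits shown, so these two values show no gap. Compound 3 `CC[C@@H](C(=O)NC)N1CCCC1=O` comes from compound 1 by the change methyl in place of phenyl on an amide-type nitrogen and so has methyl in place of phenyl on an amide-type nitrogen. Among the measured compounds shown here, no measured pair shows what this swap does. For that reason no step beyond the scatter is expected in this assay and the direction stays open, with only a slight lean toward smaller doses. The expected move is a 1.2-fold lower number from compound 1 to compound 3 (0.09 log units; within the scatter) and this estimate stays within the usual scatter. The estimate for compound 3 is 450 umol/kg with an expected range from 150 umol/kg to 1100 umol/kg in repeat measurements.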

Compound 3, dose for half-maximal effect: 1800 umol/kg
Compound 3: the middle estimate sits 4.0-fold (0.60 log units) below what was measured; the whole stated range lies below it.
By their numbers in this assay, from the lowest: compounds 1 and 2 (each within the scatter of the next); then compound 3.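

Among the compounds shown here, this is the first measured swap at this amide-type nitrogen, and it shows that the group there matters: in this assay methyl in place of phenyl gives a 3.2-fold higher number from compound 1 to compound 3 (0.51 log units; beyond the scatter) and so calls for a larger dose. The step is modest but beyond the scatter, which means the phenyl of compound 1 cannot be exchanged for methyl without a loss on this read-out, at least on this core. Nothing available explains why the dose shifts.

The compounds shown leave open whether an ethyl group, a longer chain or a cyclohexyl ring on this nitrogen would read like compound 1 or like compound 3. They also leave open whether a pyridyl ring could take the place of phenyl and keep the value of compound 1.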